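Sulfur Substituent Variation on the Shared Core, Rat Inhibition

The source may report more compounds than this note shows. Statements on the series, on what has been measured and on what is new or still open speak of the compounds shown alone.

Measured compounds:
compound 1, `Cc1nc2c(OCc3ccccc3)cccn2c1C#N`: in a functional assay on the whole organism with Rattus norvegicus as the target, with a stated time of 4 h, at a dose of 40 mg/kg by the intraperitoneal route (on this read-out lower numbers stand for less inhibition and higher numbers for more inhibition at the one dose given (going by the name of the read-out)), compound 1 gives 25%
compound 2, `CCSCc1c(C)nc2c(OCc3ccccc3)cccn12`: in this assay compound 2 gives 36%

For the measured compounds named here, compound 2 stands highest of the two numbers in this assay; the nearest is compound 1, and the one step between them, a number 11 percentage points higher from compound 1 to compound 2 (beyond the scatter), came with (ethylsulfanyl)methyl in place of cyano on an aromatic carbon.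

Compound 3, `Cc1nc2c(OCc3ccccc3)cccn2c1C[S+](C)[O-]`, is not yet measured. It differs from compound 2 by a group of 3 heavy atoms (1 carbon, 1 oxygen, 1 sulfur; no ring) in place of a group of 3 heavy atoms (2 carbon, 1 sulfur; no ring), on a saturated chain carbon bound to an aromatic carbon.

Going by the values given here, the only measured step bears on this only loosely: it exchanged the whole group on that chain carbon, whereas the change to compound 3 keeps the chain carbon and the sulfur and alters what is attached to the sulfur. Among the compounds with values here, no measured pair shows the effect of such a change, so the single modest step gives no direction to expect. For compound 3 the step is therefore expected to lie within the scatter, a number 6 percentage points lower from compound 2 to compound 3 (within the scatter). Compound 3 is estimated at 30%, with a range from 10% to 50%.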

Compound 3, a percentage reported as inhibition, in the whole organism at one dose (the size of the read-out at that dose, not a potency): 0%
Beside the measured number, compound 3's estimate is 30 percentage points above it, and the stated range ends above it.
By their numbers in this assay, from the lowest: compound 3; then compound 1; then compound 2.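

Working notes on the chain carbon: in this assay, the exchange of ethylsulfanyl for the group of 3 heavy atoms (1 carbon, 1 oxygen, 1 sulfur; no ring) gives a number 36 percentage points lower from compound 2 to compound 3 (beyond the scatter), the first large step in the series and one that shows this position is far from indifferent to what is attached to the sulfur. Set against the cyano compound, the same group gives a number 25 percentage points lower from compound 1 to compound 3 (beyond the scatter), so a sulfur held on the chain carbon does not by itself keep the read-out at the level seen for compound 2. No measurement on hand accounts for this loss.

The exchange alters two things at once, the carbon count on the sulfur and the oxygen on it, and the compounds shown do not separate the two; methylsulfanyl or ethylsulfinyl on the same chain carbon would do so. Also open, from the compounds shown here alone, is how a group without sulfur on that carbon, such as an amine or a carboxylic acid, would stand in this assay at this single dose.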